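Dihydroxypyrimidine in place of dimethylisoxazole on the amine

The source may report more compounds than this note shows. Statements on the series, on what has been measured and on what is new or still open speak of the compounds shown alone.

Measured so far:
Compound 1, `Cc1cc2c(cc1Cc1ccc(C(=O)NCC3CCCCC3)o1)C(C)(C)CCC2(C)C`, gives 1550 nM in an assay on isolated protein for binding affinity to Gonadotropin-releasing hormone receptor (Rattus norvegicus); a lower number here means a stronger inhibitor, a higher number a weaker inhibitor.
Compound 2, `Cc1cc2c(cc1Cc1ccc(C(=O)NCC3CCC(CNC(=O)C(F)(F)F)CC3)o1)C(C)(C)CCC2(C)C`, gives 2720 nM in this assay.
Compound 3, `Cc1cc2c(cc1Cc1ccc(C(=O)NCC3CCC(CNCc4c(C)noc4C)CC3)o1)C(C)(C)CCC2(C)C`, gives 1200 nM in this assay.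

Compound 3 stands lowest of the three numbers, but only one gap is beyond the scatter: a 1.3-fold lower number from compound 1 to compound 3 (0.11 log units; within the scatter), while a 2.3-fold lower number from compound 2 to compound 3 (0.36 log units; beyond the scatter). Compound 4, `Cc1cc2c(cc1Cc1ccc(C(=O)NCC3CCC(CNCc4cc(O)nc(O)n4)CC3)o1)C(C)(C)CCC2(C)C`, differs from compound 3 by 2,6-dihydroxypyrimidin-4-yl in place of 3,5-dimethyl-1,2-oxazol-4-yl on a saturated chain carbon bound to an amine nitrogen. Among the compounds with values here, the steps that bear on this change are those that varied the group on the amine nitrogen, and they moved the number little: a 1.8-fold higher number from compound 1 to compound 2 (0.24 log units; within the scatter) and a 2.3-fold lower number from compound 2 to compound 3 (0.36 log units; beyond the scatter). A change of similar small size, if any, is therefore expected, and the estimated step is a 1.3-fold higher number from compound 3 to compound 4 (0.10 log units; within the scatter). Compound 4 is expected to give 1500 nM, with a range from 600 nM to 4000 nM.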

Compound 4, inhibition constant: 865 nM
Compound 4: middle estimate off by 1.7-fold (0.24 log units), on the high side; measured number inside the range.
By their numbers in this assay, from the lowest: compounds 4, 3, 1 and 2 (each within the scatter of the next, the first and the last beyond it).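

In this assay, this place on the saturated chain carbon bound to the amine nitrogen accepts 2,6-dihydroxypyrimidin-4-yl as readily as 3,5-dimethyl-1,2-oxazol-4-yl, with a 1.4-fold lower number from compound 3 to compound 4 (0.14 log units; within the scatter), and the whole added side chain gives a 1.8-fold lower number from compound 1 to compound 4 (0.25 log units; within the scatter). Only the comparison with the trifluoromethyl carbonyl amide stands out, with a 3.1-fold lower number from compound 2 to compound 4 (0.50 log units; beyond the scatter). Nothing measured here explains why exchanging these two rings changes the number so little.

Still open, on these data alone, is whether a phenyl ring or a carboxylic acid at this place, or a longer chain before the ring, would shift the number beyond the scatter.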